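The compounds below may be only part of what the source reports. "The series", "measured", "known", "first", "only" and "open" are said of these compounds alone.

Compound 1 `Cc1cc(C)cc(S(=O)(=O)c2c(C(=O)N[C@H]3CCNC3)[nH]c3ccc(Cl)cc23)c1`: 10000 nM
Compound 2 `Cc1cc(C)cc(S(=O)(=O)c2c(C(=O)N[C@@H]3CCN(Cc4cccnc4)C3)[nH]c3ccc(Cl)cc23)c1`: 36500 nM

For the measured compounds named here, in an ADME assay on MT4 cells (Homo sapiens) for cytotoxicity, read by MTT assay, with a stated time of 5 days (a lower number here means that less compound is tolerated, a higher number that more compound is tolerated), compound 1 gives 10000 nM, the lower of the only two numbers available. Compound 3 `Cc1cc(C)cc(S(=O)(=O)c2c(C(=O)N[C@H]3CCN(Cc4ccccc4F)C3)[nH]c3ccc(Cl)cc23)c1` has not yet been measured. Its difference from compound 1 is 2-fluorobenzyl in place of hydrogen on an amine nitrogen in a ring.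

Going by the values given here, one measured step bears on this change: a 3.7-fold higher number from compound 1 to compound 2 (0.56 log units; beyond the scatter). There, 1-((pyridin-3-yl)methyl)pyrrolidin-3-yl takes the place of pyrrolidin-3-yl on an amide-type nitrogen, a modest rise beyond the usual scatter. Among the compounds with values here, no measured compound carries the 2-fluorobenzyl group, and a single step is thin evidence. A smaller rise in the same direction is therefore expected, an estimated 1.8-fold higher number from compound 1 to compound 3 (0.26 log units; within the scatter). The expected value for compound 3 is 18000 nM, within an estimated range of 6000 nM to 60000 nM.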

Compound 3, half-maximal cytotoxic concentration: 215000 nM
Estimate against measurement, compound 3: 12-fold (1.08 log units) below; measured number above the stated range.
By their numbers in this assay, from the lowest: compound 1; then compound 2; then compound 3.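

For the compounds shown here, this position on the pyrrolidine ring can shift the number far more than the earlier compounds suggested. In this assay, 2-fluorobenzyl in place of hydrogen on the amine nitrogen in a ring gives a 22-fold higher number from compound 1 to compound 3 (1.33 log units; beyond the scatter), so more of compound 3 is tolerated before the cells are affected. With a 3.7-fold higher number from compound 1 to compound 2 (0.56 log units; beyond the scatter), two different groups on this ring nitrogen now both raise the number, though by steps of different size, and no measurement here explains the rise in either case.

As far as these compounds go, how much of the rise in compound 3 belongs to the fluorine and how much to the benzyl part stays open, and a plain benzyl group on the same nitrogen would separate the two. A small methyl group there would show whether a ring is needed at all.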